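The source may hold more compounds than are shown below. What is called first, only, known or untested is meant among the compounds shown, and "the series" means these compounds.

Measured so far:
compound 1 `Cc1cc(Cl)cc(-c2ccnc3cc(CN4C(=O)C5CC5C4=O)sc23)c1O[C@@H]1CCNC[C@@H]1C` — 1.1 nM
compound 2 `Cc1cc(Cl)cc(-c2ccnc3cc(CN4C(=O)C5CC5C4=O)sc23)c1C[C@@H]1CNC[C@@H](C)O1` — 0.39 nM

Going by the values given here, in an assay on isolated protein for inhibition of ubiquitin carboxyl-terminal hydrolase 7 (Homo sapiens), read by fluorescence, with stated times of 30 min and 1 h (a higher number here means a weaker inhibitor, a lower number a stronger inhibitor), compound 1 gives 1.1 nM, the higher of the two numbers; the only measured step runs a 2.8-fold lower number from compound 1 to compound 2 (0.45 log units; beyond the scatter), and compound 2 gives 0.39 nM. Compound 3 `Cc1cc(Cl)cc(-c2ccnc3cc(CN4C(=O)C5C(C4=O)C5(C)C)sc23)c1O[C@@H]1CCNC[C@@H]1C` differs from compound 1 by a group of 10 heavy atoms (7 carbon, 1 nitrogen, 2 oxygen; one three-membered non-aromatic ring of carbon only, one five-membered non-aromatic ring with 1 hetero atom) in place of a group of 8 heavy atoms (5 carbon, 1 nitrogen, 2 oxygen; one three-membered non-aromatic ring of carbon only, one five-membered non-aromatic ring with 1 hetero atom), on a saturated chain carbon bound to an aromatic carbon. The (3-methylpiperidin-4-yl)oxy group, the part varied in the measured step, is kept. No measured step touches the group on the saturated chain carbon bound to an aromatic carbon, so nothing shown sizes this change. With the one relevant part held constant, no step beyond the scatter is expected in this assay; the expected step is a 1.4-fold higher number from compound 1 to compound 3 (0.13 log units; within the scatter). Compound 3 is estimated at 1.5 nM, range 0.5 nM to 5 nM.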

Compound 3, half-maximal inhibitory concentration: 0.18 nM
The estimate for compound 3 lay 8.3-fold (0.92 log units) above the measured number; measured number outside the range, below it.
By their numbers in this assay, from the lowest: compound 3; then compound 2; then compound 1.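

In this assay, the group on a saturated chain carbon bound to an aromatic carbon proves to be a position that moves the number: the 10-heavy-atom group in place of the 8-heavy-atom group gives a 6.1-fold lower number from compound 1 to compound 3 (0.79 log units; beyond the scatter). The added carbon is accepted here, with the ring count and hydrogen-bond acceptor count unchanged. Nothing available explains this step.

From the compounds shown here alone, whether a single methyl or an ethyl on the three-membered ring would give a similar step remains open. Also open, going by these compounds, is whether this change adds to the (6-methylmorpholin-2-yl)methyl change.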